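The source may report more compounds than this note shows. Statements on the series, on what has been measured and on what is new or still open speak of the compounds shown alone.

In a functional assay on A2780 cells (Homo sapiens) for cytotoxicity, read by MTT assay, with a stated time of 24 h (on this read-out lower numbers stand for stronger inhibition and higher numbers for weaker inhibition), compound 1 `CCCCC[C@@H](C[C@@H](O)C[C@@H]1CC=CC(=O)O1)OC` gives 49400 nM, the top of the three numbers, though compound 2 `CCCCC[C@@H](C[C@@H](O)C[C@H]1CC=CC(=O)O1)OC`, at 33700 nM, lies within the scatter of it. Compound 3 `CCCCC[C@@H](CCC[C@@H]1CC=CC(=O)O1)OC` gives 14900 nM, clearly lower. Compound 4 `CCCCC[C@H](C[C@H](O)C[C@H]1CC=CC(=O)O1)OC` is not yet measured, and its relation to compound 1 is this: the two compounds have the same atoms and bonds and differ only in configuration as drawn: 3 of 3 stereo elements differ (all stereocentres are inverted: mirror images); a stereocentre at a saturated chain carbon is drawn S in compound 1 and R in compound 4; a stereocentre at a saturated chain carbon is drawn R in compound 1 and S in compound 4; a stereocentre at a saturated ring carbon is drawn S in compound 1 and R in compound 4. Only one inversion has a measured counterpart, a 1.5-fold lower number from compound 1 to compound 2 (0.17 log units; within the scatter), which changes the stereocentre at a saturated ring carbon alone. The other measured change, a 3.3-fold lower number from compound 1 to compound 3 (0.52 log units; beyond the scatter), swaps hydroxy for hydrogen, which does not happen here. From the compounds shown here alone, the two chain centres are untested, so no step beyond the scatter is expected in this assay. The estimated change is a 1.3-fold lower number from compound 1 to compound 4 (0.11 log units; within the scatter). For compound 4 the estimated value is 38000 nM, with an expected range of 16000 nM to 85000 nM.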

Compound 4, half-maximal inhibitory concentration: 44000 nM
Beside the measured number, compound 4's estimate is 1.2-fold (0.06 log units) below it; low and high end bracket the measured number.
By their numbers in this assay, from the lowest: compound 3; then compounds 2, 4 and 1 (each within the scatter of the next).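

Inverting all three stereocentres gives only a 1.1-fold lower number from compound 1 to compound 4 (0.05 log units; within the scatter) in this assay, so this mirror-image pair cannot be told apart on this read-out. The two saturated chain stereocentres, untested until now, show no effect beyond the scatter when inverted together, with a 1.3-fold higher number from compound 2 to compound 4 (0.12 log units; within the scatter). Among these compounds, configuration at these three centres therefore produces no step beyond the scatter, and only the loss of hydroxy does.

From the compounds shown here alone, the two chain stereocentres change together here, so the effect of inverting either one alone stays open. So does the effect of an amine in place of the hydroxy.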